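Bromo in place of hydrogen: compound 2 to compound 4

The source may hold more compounds than are shown below. What is called first, only, known or untested is meant among the compounds shown, and "the series" means these compounds.

Compound 2 `O=c1oc2ccccc2cc1-c1cn2nc(Cc3ccc(Cl)cc3)sc2n1` sits at a limit in a functional assay on HeLa cells (Homo sapiens) for cytotoxicity, with a stated time of 72 h; a higher number here means a weaker inhibitor, a lower number a stronger inhibitor: its value of > 10000 nM is a limit of the assay and not a number. Compound 1 `Fc1ccc(-c2cn3nc(Cc4ccc(Cl)cc4)sc3n2)cc1` also returns a limit, giving > 250000 nM in this assay. Compound 3 `Clc1ccc(Cc2nn3c(Br)c(-c4ccc(Cl)cc4)nc3s2)cc1` likewise returns a limit, > 250000 nM, in this assay. Among the compounds with values here, of the three values shown, one sits at the limit of > 10000 nM in this assay, at which 1 of the 3 values shown sits, and two sit at the limit of > 250000 nM in this assay, at which 2 of the 3 values shown sit; no compound has a numeric half-maximal inhibitory concentration, so compound 2 can only be placed among limits. Compound 4 `O=c1oc2ccccc2cc1-c1nc2sc(Cc3ccc(Cl)cc3)nn2c1Br` is to be measured in this assay. It differs from compound 2 by bromo in place of hydrogen on an aromatic carbon. Within the data shown here, no measured pair shows what this change does. With two of the three values at the limit of > 250000 nM in this assay, at which 2 of the 3 values shown sit, and one at the limit of > 10000 nM in this assay, at which 1 of the 3 values shown sits, nothing points to a step beyond the scatter, and a further limit is the most likely outcome. The estimate for compound 4 is 50000 nM (range 8000 nM to 300000 nM). The step from compound 2 to compound 4 is expected to be a step that the limit leaves unreadable from compound 2 to compound 4.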

Compound 4, half-maximal inhibitory concentration: 4500 nM
Beside the measured number, compound 4's estimate is 11-fold (1.05 log units) above it; the whole stated range lies above it.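

In this assay, bromo in place of hydrogen on an aromatic carbon of the five-membered aromatic ring gives an at least 2.2-fold lower number from compound 2 to compound 4 (0.34 log units; beyond the scatter), the first step in the series that can be read, and compound 4 is the only compound shown with a numeric half-maximal inhibitory concentration. The starting point of this step is a limit and not a number, so its full size stays unknown: the limit of > 10000 nM in this assay, at which 1 of the 4 values shown sits.

Compound 3 carries bromo on the same aromatic carbon, and its value of > 250000 nM is a limit of the assay.

Compound 3 differs from compound 4 in more than one place, so no pair shown tests whether the bromo step holds with another group on the core. As far as these compounds go, whether chloro, methyl or an amine on this carbon would give a similar step also stays open.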